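The source may report more compounds than this note shows. Statements on the series, on what has been measured and on what is new or still open speak of the compounds shown alone.

Compound 1 `CCCCCCCCCCCCCCNC(=O)[C@@H](NC(=O)c1nccc2ccccc12)[C@@H](C)O` gives, in a functional assay on SW-620 cells (Homo sapiens) for cytotoxicity, read by MTT assay, with a stated time of 48 h (a lower number here means a stronger inhibitor, a higher number a weaker inhibitor), a value of 30400 nM. Compound 2 `CCCCCCCCCCCCCCNC(=O)[C@@H](NC(=O)c1cc2ccccc2[nH]1)[C@@H](C)O` differs from it by 1H-indol-2-yl in place of isoquinolin-1-yl on a carbonyl carbon, and in this assay compound 2 gives 15200 nM, which makes a 2.0-fold lower number from compound 1 to compound 2 (0.30 log units; within the scatter). Compound 3 `CCCCCCCCCCCCCCCCCCNC(=O)[C@@H](NC(=O)c1nccc2ccccc12)[C@@H](C)O` differs from compound 1 by butyl in place of hydrogen on a saturated chain carbon, ten or more bonds along the chain from an amide-type nitrogen; in this assay compound 3 gives 136000 nM, a step of a 4.5-fold higher number from compound 1 to compound 3 (0.65 log units; beyond the scatter). Of the three, compound 3 has the highest number, with both other compounds beyond the scatter.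

Compound 4 `CCCCCCCCCCCCCCCCCCNC(=O)[C@@H](NC(=O)c1cc2ccccc2[nH]1)[C@@H](C)O` has not yet been measured. Against compound 3 it carries 1H-indol-2-yl in place of isoquinolin-1-yl on a carbonyl carbon, the same kind of change as the one from compound 1 to compound 2, and the place lines for the two changes read the same. The cores on which the change is made differ by butyl in place of hydrogen on a saturated chain carbon, ten or more bonds along the chain from an amide-type nitrogen.

For compound 4 in this assay the expected step from compound 3 is a 2.0-fold lower number from compound 3 to compound 4 (0.30 log units; within the scatter), resting on the earlier pairing, where the step was a 2.0-fold lower number from compound 1 to compound 2 (0.30 log units; within the scatter), though a change that size lies within the scatter. Compound 4 is therefore estimated at 68000 nM, with a likely range from 30000 nM to 200000 nM.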

Compound 4, half-maximal inhibitory concentration: 23600 nM
Compound 4: middle estimate off by 2.9-fold (0.46 log units), on the high side; the measured number lies below the stated range.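

Moved onto the core of compound 3, the change from isoquinolin-1-yl to 1H-indol-2-yl gives a 5.8-fold lower number from compound 3 to compound 4 (0.76 log units; beyond the scatter) in this assay, so it does not carry over at the size seen on the core of compound 1: the same change on two cores in this assay, a 2.0-fold lower number (0.30 log units; within the scatter) from compound 1 to compound 2 and a 5.8-fold lower number (0.76 log units; beyond the scatter) from compound 3 to compound 4, 2.9-fold (0.46 log units) apart, beyond the scatter of two such steps

With 1H-indol-2-yl in place, butyl in place of hydrogen on the chain gives a 1.6-fold higher number from compound 2 to compound 4 (0.19 log units; within the scatter), so in these compounds the effect of each change depends on the other: the same change on two cores in this assay, a 4.5-fold higher number (0.65 log units; beyond the scatter) from compound 1 to compound 3 and a 1.6-fold higher number (0.19 log units; within the scatter) from compound 2 to compound 4, 2.9-fold (0.46 log units) apart, beyond the scatter of two such steps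

These four compounds form a single comparison, which shows that the two steps cannot simply be added here but does not show why, or whether the same holds on any other core.

The compounds shown leave open how the numbers run with a shorter or a longer chain on either group. They also leave open what a phenyl group on the same carbonyl carbon would give in place of isoquinolin-1-yl or 1H-indol-2-yl.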